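The compounds below may be only part of what the source reports. "The series", "measured", "known", "first", "only" and "open" are said of these compounds alone.

Notes on the series built on the core of compound 1 `CCOC(=O)C1=Cc2ccccc2OC1(OCc1cn(CC(=O)NC2CCCCC2)nn1)C(F)(F)F`. Within the data shown here, in a functional assay on HeLa cells (Homo sapiens) for inhibition, read by MTT assay, with a stated time of 24 h (a lower number here means a stronger inhibitor, a higher number a weaker inhibitor), compound 1 gives 11400 nM, which is the only number so far in this assay. Compound 2 `CCOC(=O)C1=Cc2ccccc2OC1(OCc1cc(-c2ccc3ccccc3c2)no1)C(F)(F)F` returns only a limit in this assay, > 150000 nM, as recorded in the limit of > 150000 nM in this assay, at which 1 of the 2 values shown sits. Compound 3 `CCOC(=O)C1=Cc2ccccc2OC1(OCc1cn(CC(=O)Nc2ccccc2Br)nn1)C(F)(F)F` differs from compound 1 by 2-bromophenyl in place of cyclohexyl on an amide-type nitrogen. Among the measured compounds shown here, no measured pair shows this change, so the expected step of a 1.1-fold lower number from compound 1 to compound 3 (0.06 log units; within the scatter) is set near no change beyond the scatter, with wide uncertainty in either direction. Compound 3 is accordingly estimated at 10000 nM, within the range 3000 nM to 40000 nM.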

Compound 3, half-maximal inhibitory concentration: > 150000 nM
Compound 3 was reported as a limit (the forecaster's own chance of this, stated with the estimate: 20%); middle value at least 15-fold (1.17 log units) from the limit.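

On the amide-type nitrogen, 2-bromophenyl in place of cyclohexyl gives an at least 13-fold higher number from compound 1 to compound 3 (1.11 log units; beyond the scatter) in this assay, so this position responds strongly to the group it carries, which compound 2, changed elsewhere in the structure, could not show. The value for compound 3 is a limit of the assay and not a number: the limit of > 150000 nM in this assay, at which 2 of the 3 values shown sit.

Still open, as far as these compounds go, is whether unsubstituted phenyl on this nitrogen would sit with compound 1 or with compound 3, which would separate the effect of the ring from that of the bromine. Equally open, from the compounds shown here alone, is whether cyclopentyl or an open butyl chain would keep the activity of compound 1.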